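Swapping an Ester Chain for a Branched Alcohol

This account rests on a few compounds, and the source may have more. Where it says the series, first, only, none or still open, it means among the compounds named here.

In a functional assay on PC-3 cells (Homo sapiens) for antiproliferative activity, read by MTT assay, with a stated time of 24 h (on this read-out higher numbers stand for weaker inhibition and lower numbers for stronger inhibition), compound 1 `CCn1c(C(=O)NCC(=O)OC)ccc1C(CC)(CC)c1ccc(OCS(=O)(=O)c2ccccc2)c(C)c1` gives only a limit, > 50000 nM. Compound 2 `CCn1c(C(=O)NCCC(=O)OC)ccc1C(CC)(CC)c1ccc(OCS(=O)(=O)c2ccccc2)c(C)c1` gives 40400 nM, the higher of the two actual numbers, while compound 3 `CCn1c(C(=O)NCCO)ccc1C(CC)(CC)c1ccc(OCS(=O)(=O)c2ccccc2)c(C)c1` gives 17700 nM. Compound 4 `CCn1c(C(=O)N[C@H](C)CO)ccc1C(CC)(CC)c1ccc(OCS(=O)(=O)c2ccccc2)c(C)c1` differs from compound 2 by one change: 1-(hydroxymethyl)ethyl in place of 2-(methoxycarbonyl)ethyl on an amide-type nitrogen. Here, 1-(hydroxymethyl)ethyl stands in place of 2-(methoxycarbonyl)ethyl on an amide-type nitrogen. The closest guide is the modest step of a 2.3-fold lower number from compound 2 to compound 3 (0.36 log units; beyond the scatter), in which hydroxy replaces methoxycarbonyl on a saturated chain carbon. The step of an at least 2.8-fold lower number from compound 1 to compound 3 (0.45 log units; beyond the scatter) points the same way, whereas an at least 1.2-fold lower number from compound 1 to compound 2 (0.09 log units; that floor lies within the scatter) is a floor that lies within the scatter. For the measured compounds named here, no measured step covers the branching or the defined stereocentre. A similarly modest fall in the number is therefore expected in this assay, with compound 4 landing near compound 3. The expected change is a 2.2-fold lower number from compound 2 to compound 4 (0.35 log units; beyond the scatter). Compound 4 is estimated at 18000 nM, with an expected range of 8000 nM to 40000 nM.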

Compound 4, half-maximal inhibitory concentration: 7790 nM
Beside the measured number, compound 4's estimate is 2.3-fold (0.36 log units) above it; measured number below the stated range.
By their numbers in this assay, from the lowest: compound 4; then compound 3; then compound 2. At a limit, above all of these: compound 1.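

The methyl group on the saturated chain carbon is the new finding: a 2.3-fold lower number from compound 3 to compound 4 (0.36 log units; beyond the scatter), so branching adds to what the hydroxy-bearing chain of compound 3 had already shown in this assay. The full exchange of 2-(methoxycarbonyl)ethyl for 1-(hydroxymethyl)ethyl on the amide-type nitrogen gives a 5.2-fold lower number from compound 2 to compound 4 (0.71 log units; beyond the scatter), a larger step than the earlier 2.3-fold lower number from compound 2 to compound 3 (0.36 log units; beyond the scatter). The step of an at least 6.4-fold lower number from compound 1 to compound 4 (0.80 log units; beyond the scatter) is only a floor, since the value it starts from is a limit: the limit of > 50000 nM in this assay, at which 1 of the 4 values shown sits.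

Only one configuration of the defined stereocentre appears, so the methyl group and the stereocentre cannot be told apart in the step from compound 3. Also open, as far as these compounds go, is how the opposite configuration, a longer branched chain, or an amine in place of the hydroxy would read in this assay.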